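The source may report more compounds than this note shows. Statements on the series, on what has been measured and on what is new or still open speak of the compounds shown alone.

Compound 1 `COc1ccccc1NC(=O)CCc1cccc2c1B(O)OC2`: 930 nM
Compound 2 `C#Cc1ccccc1NC(=O)CCc1cccc2c1B(O)OC2`: 1300 nM

Both numbers come from a functional assay on MDA-MB-231 cells (Homo sapiens) for antiproliferative activity, read by MTT assay, with a stated time of 72 h; on this read-out higher numbers stand for weaker inhibition and lower numbers for stronger inhibition. Compound 2 lies within the scatter of compound 1, so the two cannot be ranked. Compound 3 `O=C(CCc1cccc2c1B(O)OC2)Nc1ccccc1-c1ccccc1` differs from compound 2 in one place: phenyl in place of ethynyl on an aromatic carbon. Put simply, it has phenyl in place of ethynyl on an aromatic carbon, ortho to a large group.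

Going by the values given here, only one measured step bears on this change. It is a 1.4-fold higher number from compound 1 to compound 2 (0.15 log units; within the scatter), with ethynyl in place of methoxy on an aromatic carbon. Among the compounds with values here, no measured compound carries phenyl there, so this single step is a weak guide. With that caution, no change beyond the scatter is expected in this assay.

The expected step is a 1.2-fold higher number from compound 2 to compound 3 (0.06 log units; within the scatter).

Compound 3 is estimated at 1500 nM, with an expected range of 500 nM to 4500 nM.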

Compound 3, half-maximal inhibitory concentration: 18000 nM
Estimate against measurement, compound 3: 12-fold (1.08 log units) below, outside the stated range (above it).
By their numbers in this assay, from the lowest: compounds 1 and 2 (each within the scatter of the next); then compound 3.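

Until now, methoxy and ethynyl on this aromatic carbon could not be ranked, so the position might have seemed to tolerate any group. Phenyl shows otherwise: in this assay, replacing ethynyl with phenyl gives a large loss of activity (a 14-fold higher number from compound 2 to compound 3 (1.14 log units; beyond the scatter)), and replacing methoxy with phenyl gives a similar one (a 19-fold higher number from compound 1 to compound 3 (1.29 log units; beyond the scatter)), so what sits on this carbon, ortho to a large group, can matter greatly. No measurement at hand gives a reason for this loss. Going by these compounds, it remains open whether any group here, such as an amine or a fluorine atom, could give a lower number than compound 1 and compound 2. Also open, on these data alone, is whether the loss follows from the aromatic ring or simply from the count of heavy atoms, which a cyclohexyl group or a longer chain could help to separate.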